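Pentafluorophenoxy ketone: estimating compound 4 from fluorinated analogues

The source may hold more compounds than are shown below. What is called first, only, known or untested is meant among the compounds shown, and "the series" means these compounds.

Compound 1, `CC(=O)Nc1cccc(OCC(=O)[C@H](CC(=O)O)NC(=O)[C@@H](NC(=O)COc2cccc3ccccc23)C(C)C)c1`, in a functional assay on Jurkat cells (Homo sapiens) (on this read-out higher numbers stand for weaker inhibition and lower numbers for stronger inhibition), gives > 100000 nM, a limit of the assay rather than a number.
Compound 2, `CC(C)[C@H](NC(=O)COc1cccc2ccccc12)C(=O)N[C@@H](CC(=O)O)C(=O)COc1cc(F)ccc1F`, gives > 100000 nM, again a limit and not a number.
Compound 3, `CC(C)[C@H](NC(=O)COc1cccc2ccccc12)C(=O)N[C@@H](CC(=O)O)C(=O)COc1cc(F)c(F)cc1F`, gives 39300 nM.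

Compound 1 thus stands at the limit of > 100000 nM in this assay, at which 2 of the 3 values shown sit, and only compound 3 offers a number. Compound 4 is `CC(C)[C@H](NC(=O)COc1cccc2ccccc12)C(=O)N[C@@H](CC(=O)O)C(=O)COc1c(F)c(F)c(F)c(F)c1F`; it differs from compound 1 by 2,3,4,5,6-pentafluorophenyl in place of 3-acetamidophenyl on an oxygen on a saturated carbon. For the measured compounds named here, two measured steps bear on this change. The step of an at least 2.5-fold lower number from compound 1 to compound 3 (0.40 log units; beyond the scatter) exchanges the same 3-acetamidophenyl for 2,4,5-trifluorophenyl, and the step of an at least 2.5-fold lower number from compound 2 to compound 3 (0.40 log units; beyond the scatter) shows that fluoro in place of hydrogen on an aromatic carbon lowered the number further. Going by these compounds, both sizes are read against a limit, so their full extent is unknown. The 2,3,4,5,6-pentafluorophenyl of compound 4 carries fluoro on every aromatic carbon, beyond the 2,4,5-trifluorophenyl of compound 3, so a lower number than for compound 1 is expected, in the direction of the two steps seen and of comparable or larger size. The estimate for compound 4 in this assay is therefore 20000 nM, within 5000 nM to 100000 nM, which is expected to amount to an at least 5.0-fold lower number from compound 1 to compound 4 (0.69 log units; beyond the scatter).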

Compound 4, half-maximal inhibitory concentration: 3050 nM
Compound 4: middle estimate off by 6.6-fold (0.82 log units), on the high side; the measured number lies below the stated range.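

For the compounds shown here, on an oxygen on a saturated carbon, 2,3,4,5,6-pentafluorophenyl gives in this assay a result well clear of the limit, with a 13-fold lower number from compound 3 to compound 4 (1.11 log units; beyond the scatter), the only step here between two actual numbers. Against the other two groups, the change reaches an at least 32-fold lower number from compound 1 to compound 4 (1.51 log units; beyond the scatter) and an at least 32-fold lower number from compound 2 to compound 4 (1.51 log units; beyond the scatter), sizes that are only minimums: the limit of > 100000 nM in this assay, at which 2 of the 4 values shown sit. The earlier compounds shown here had given only a minimum size for the fluoro step, whereas this series of fluorinated phenyl groups now has a measured size.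

Going by these compounds, how 2,3,5,6-tetrafluorophenyl or unsubstituted phenyl would read at this place stays open, as does whether chloro or trifluoromethyl could stand in for fluoro. On these data alone, whether the step would carry over to a core other than the shared core also remains open.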